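A Methyl-to-Chloro Swap on Three Weakly Active Triazoles

The source may report more compounds than this note shows. Statements on the series, on what has been measured and on what is new or still open speak of the compounds shown alone.

Compound 1 `Cc1c(O)ccc2c1[C@H](Cn1cc(-c3ccc(Cl)cc3)nn1)[C@@]13CC(=O)[C@@](C)(CC[C@@H]21)C3` and compound 2 `Cc1ccc(-c2cn(C[C@H]3c4c(ccc(O)c4C)[C@@H]4CC[C@@]5(C)C[C@]43CC5=O)nn2)cc1` share one core, while compound 3 `C=C1C[C@]23C[C@@]1(O)CC[C@H]2c1cc(Br)c(O)c(C)c1[C@@H]3Cn1cc(-c2ccc(C)cc2)nn1` carries another; how the two cores differ is not broken down here. In a functional assay on SW480 cells (Homo sapiens) for cytotoxicity, read by MTT assay, with a stated time of 4 days (a lower number here means a stronger inhibitor, a higher number a weaker inhibitor), compound 1 gives > 20000 nM, which is a limit of the assay rather than a number. Compound 2 likewise gives only a limit, > 20000 nM. Compound 3 also gives only a limit, > 20000 nM. Going from compound 2 to compound 1 the change is chloro in place of methyl on an aromatic carbon, and the step that the two limits leave unreadable from compound 2 to compound 1 cannot be read because both ends sit at the limit of > 20000 nM in this assay, at which 3 of the 3 values shown sit. Compound 4 `C=C1C[C@]23C[C@@]1(O)CC[C@H]2c1cc(Br)c(O)c(C)c1[C@@H]3Cn1cc(-c2ccc(Cl)cc2)nn1` is not yet measured; it differs from compound 3 by chloro in place of methyl on an aromatic carbon, the same change made at the same place. Since the earlier pair gave no readable step, the step from compound 3 to compound 4 is expected to be a step that the limit leaves unreadable from compound 3 to compound 4, an expectation that rests on compound 3 standing at the limit of > 20000 nM in this assay, at which 3 of the 3 values shown sit. Compound 4 is therefore estimated at 30000 nM, most likely reported again only as a limit, within a range from 10000 nM to 80000 nM.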

Compound 4, half-maximal inhibitory concentration: 18000 nM
Compound 4: the middle estimate sits 1.7-fold (0.22 log units) above what was measured, and the stated range covers the measured number.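

In this assay, replacing 4-methylphenyl with 4-chlorophenyl on the second core gives an at least 1.1-fold lower number from compound 3 to compound 4 (0.04 log units; that floor lies within the scatter), and this figure is only a floor, not a measured size, so on its own it does not establish any real difference between the two compounds. Going by these compounds, the true size of the step stays unknown because one end of it rests on a limit rather than a number: the limit of > 20000 nM in this assay, at which 3 of the 4 values shown sit. The same swap on the shared core of compound 1 and compound 2 cannot be read at all, so this series shows neither that the change carries from one core to the other nor that it fails to.

The compounds shown leave open how other groups in the same place on the phenyl ring, such as an amine, a methoxy group or a carboxylic acid, would read in this assay. They also leave open how large the swap is on either core, since that would take a number rather than a limit at both ends of a pair.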